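The source may hold more compounds than are shown below. What is called first, only, known or untested is meant among the compounds shown, and "the series" means these compounds.

Measured so far:
- compound 1, `COc1ccccc1-c1cnc(C(=O)CCCCCCc2ccccc2)o1`, gives 400 nM
- compound 2, `N#Cc1cccc(-c2cnc(C(=O)CCCCCCc3ccccc3)o2)c1`, gives 15 nM
- compound 3, `O=C(CCCCCCc1ccccc1)c1ncc(-c2ccc(F)cc2)o1`, gives 62 nM

All three share one core and differ only in the aromatic group attached to it. In an assay (Rattus norvegicus) for inhibition of Fatty-acid amide hydrolase 1 (Homo sapiens) (a lower number here means a stronger inhibitor, a higher number a weaker inhibitor), compound 3 stands second highest of the three numbers: compound 2 is its nearest neighbour, with a 4.1-fold higher number from compound 2 to compound 3 (0.62 log units; beyond the scatter), and compound 1 is furthest away, with a 6.5-fold lower number from compound 1 to compound 3 (0.81 log units; beyond the scatter).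

Compound 4, `COc1ccnc(-c2cnc(C(=O)CCCCCCc3ccccc3)o2)c1`, has not yet been measured. It differs from compound 3 in one place: 4-methoxypyridin-2-yl in place of 4-fluorophenyl on an aromatic carbon.

For the measured compounds named here, the steps that bear on this are the two that swap the same aromatic group. Replacing 2-methoxyphenyl by 4-fluorophenyl gave a 6.5-fold lower number from compound 1 to compound 3 (0.81 log units; beyond the scatter), and replacing 3-cyanophenyl by 4-fluorophenyl gave a 4.1-fold higher number from compound 2 to compound 3 (0.62 log units; beyond the scatter). Going by the values given here, the only compound with a methoxy group, compound 1, has the highest number, while the group with an extra acceptor, in compound 2, has the lowest. Among the compounds with values here, the incoming group carries both a methoxy and a ring nitrogen, so these pointers pull in opposite directions, and no step with a pyridine ring exists here.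

Compound 4 is therefore expected to change this assay modestly at most, with a 1.8-fold lower number from compound 3 to compound 4 (0.25 log units; within the scatter), giving an estimated 35 nM (range 8 nM to 150 nM).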

Compound 4, inhibition constant: 0.8 nM
For compound 4 the middle estimate is 44-fold (1.64 log units) above the measured one, and the stated range ends above it.
By their numbers in this assay, from the lowest: compound 4; then compound 2; then compound 3; then compound 1.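

In this assay, this place on the shared core can give far lower numbers than the three phenyl-bearing compounds suggested: putting 4-methoxypyridin-2-yl in place of 4-fluorophenyl gives a 78-fold lower number from compound 3 to compound 4 (1.89 log units; beyond the scatter), and the same group also improves on the 3-cyanophenyl group, with a 19-fold lower number from compound 2 to compound 4 (1.27 log units; beyond the scatter). A methoxy group on the ring does not by itself go with a high number, since the two compounds that carry one sit at opposite ends of the series, with a 500-fold lower number from compound 1 to compound 4 (2.70 log units; beyond the scatter), although these two rings differ both in the ring nitrogen and in where the methoxy stands. Nothing available here explains why this group gives such a low number.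

The compounds shown leave open whether the ring nitrogen, the methoxy group or the two together lie behind these steps, and a plain pyridin-2-yl group and a 4-methoxyphenyl group at this place would separate them. Also open, on these data alone, is what an ethoxy group or an amine would do in place of the methoxy on the pyridine ring.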